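A few compounds are considered here, and "the series" means these few. Any claim that something is new, unique, unknown or untested is made for them only; others in the source may bear on it.

Measured compounds in the series:

- compound 1, `CCCS(=O)(=O)Nc1ccc(F)c(C(=O)c2n[nH]c3ncc(-c4ccc(Cl)cc4Cl)cc23)c1F`: 22%
- compound 2, `CCCS(=O)(=O)Nc1ccc(F)c(C(=O)c2n[nH]c3ncc(-c4ccc(S(=O)(=O)NCC)cc4)cc23)c1F`: 3%

Compound 2 gives the lowest of the two numbers seen in an assay for binding affinity to dual specificity mitogen-activated protein kinase kinase 4 (Homo sapiens), read by KINOMEscan, tested at 100 nM; a lower number here means a stronger effect, a higher number a weaker effect of the compound at the concentration tested; the nearest is compound 1, which reads a number 19 percentage points lower from compound 1 to compound 2 (beyond the scatter) higher. That one step replaced 2,4-dichlorophenyl with 4-(ethylsulfamoyl)phenyl on an aromatic carbon and produced a modest drop.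

Compound 3, `CCCS(=O)(=O)Nc1ccc(F)c(C(=O)c2n[nH]c3ncc(-c4ccc(NS(C)(=O)=O)cc4)cc23)c1F`, is not yet measured in this assay. It differs from compound 2 by methanesulfonamido in place of ethylsulfamoyl on an aromatic carbon; the place is an aromatic carbon of a six-membered aromatic ring of carbon only, para to a large group.

Within the data shown here, no measured step changes this part of the molecule; the step from compound 1 to compound 2 alters the whole aryl group and so bears only indirectly. Both groups carry the same count of donors and acceptors, and compound 2 already sits near the bottom of the scale, leaving little room downward. The expectation for compound 3 is therefore a step of a number 4 percentage points higher from compound 2 to compound 3 (within the scatter), not beyond the scatter. Compound 3 is estimated at 7%, within the range 1% to 25%.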

Compound 3, a percentage reported as activity, at one concentration (the size of the read-out at that concentration, not a potency): 0.85%
Estimate against measurement, compound 3: 6.2 percentage points above; measured number below the stated range.
By their numbers in this assay, from the lowest: compounds 3 and 2 (each within the scatter of the next); then compound 1.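

In this assay, methanesulfonamido in place of ethylsulfamoyl, on an aromatic carbon para to a large group, gives a number 2.2 percentage points lower from compound 2 to compound 3 (within the scatter), so this position accepts the exchange without a reading that can be told apart from that of compound 2, although one group replaces the other at the same place and the two differ in their heavy atoms. The comparison with the dichlorinated aryl group now has a second member, since 4-(methanesulfonamido)phenyl in place of 2,4-dichlorophenyl gives a number 21.2 percentage points lower from compound 1 to compound 3 (beyond the scatter), which puts it alongside the earlier step to 4-(ethylsulfamoyl)phenyl; within these three compounds, compound 1 stands apart and compound 2 and compound 3 read alike. No supporting data bear on why these aryl groups read as they do.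

With compound 2 at 3% and compound 3 at 0.85%, both close to the bottom of the scale at a single concentration, any real difference in affinity between them stays hidden. Also open, as far as these compounds go, is whether a plain amine, a carboxylic acid or a longer chain on the sulfonyl group at this place would read like compound 3 or like compound 1.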